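Stereochemical inversion at a ring carbon of compound 1

A few compounds are considered here, and "the series" means these few. Any claim that something is new, unique, unknown or untested is made for them only; others in the source may bear on it.

Compound 1 `CC1(C)O[C@H]2O[C@H]([C@H](CCO)n3cnc4c(N)ncnc43)[C@H](OCc3ccccc3)[C@H]2O1` is the reference point for this step. In an ADME assay on Vero cells (Chlorocebus sabaeus) for cytotoxicity, read by fluorescence and resazurin assay, with a stated time of 3 days (a higher number here means that more compound is tolerated, a lower number that less compound is tolerated), compound 1 gives 97100 nM. Within the three numbers available, compound 1 has the highest, but its nearest neighbour compound 2 `COC(=O)C[C@@H]([C@H]1O[C@@H]2OC(C)(C)O[C@@H]2[C@H]1OCc1ccccc1)n1cnc2c(N)ncnc21` with 68400 nM and its furthest neighbour compound 3 `CC1(C)O[C@H]2O[C@H]([C@H](CC(=O)O)n3cnc4c(N)ncnc43)[C@H](Oc3ccccc3N)[C@H]2O1` with 67100 nM both lie within the scatter of it, so no ordering among the three can be claimed. Among the compounds with values here, the one measured step that changes a single place, a 1.4-fold lower number from compound 1 to compound 2 (0.15 log units; within the scatter), is itself within the scatter.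

Compound 4 `CC1(C)O[C@H]2O[C@H]([C@H](CCO)n3cnc4c(N)ncnc43)[C@@H](OCc3ccccc3)[C@H]2O1` is not yet measured. Its relation to compound 1 is the two compounds have the same atoms and bonds and differ only in configuration as drawn: 1 of 5 stereo elements differ; a stereocentre at a saturated ring carbon is drawn S in compound 1 and R in compound 4. Within the data shown here, no measured step among the three compounds touches configuration at all; the one single-place step concerns a substituent on the chain and is within the scatter. Nothing in the available numbers therefore argues for a step in either direction, and the expectation for a 1.1-fold lower number from compound 1 to compound 4 (0.03 log units; within the scatter) is a step that stays within the scatter around compound 1.

For compound 4 the estimate in this assay is 90000 nM, expected to fall in the range from 40000 nM to 200000 nM.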

Compound 4, half-maximal cytotoxic concentration: 148000 nM
Compound 4: the middle estimate sits 1.6-fold (0.22 log units) below what was measured; measured number inside the range.
By their numbers in this assay, from the lowest: compounds 3, 2, 1 and 4 (each within the scatter of the next, the first and the last beyond it).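

In this assay, within the data shown here, redrawing a stereocentre at a saturated ring carbon from S to R gives a 1.5-fold higher number from compound 1 to compound 4 (0.18 log units; within the scatter), the first measured step that touches configuration rather than a substituent. At this position, therefore, the drawn configuration gives no readable difference in cytotoxicity on Vero cells, and neither configuration can be ranked above the other on this pair alone. The reading is a direct one for this stereocentre, with no change of substituent to separate from it, and it rests on a single pair of compounds: the fact that compounds 1 and 4 differ only in the configuration as drawn

From the compounds shown here alone, it remains open whether the remaining stereo elements of the shared core would give an equally small step on inversion, and whether this stereocentre would behave the same way with a different chain, such as a longer chain, or with an amine in place of the hydroxymethyl group. Also open, going by these compounds, is whether the R configuration would stay within the scatter when paired with the methoxycarbonyl of compound 2, since the configuration step is so far seen with the hydroxymethyl chain only.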